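The source may hold more compounds than are shown below. What is called first, only, known or untested is meant among the compounds shown, and "the series" means these compounds.

Compound 3, with the structure `Cc1ncc(CO)c2c(Nc3ccccn3)c(NC(C)(C)C)oc12`, stands without a single number: in a functional assay on HEK293 cells for agonist activity at Toll-like receptor 8 (Homo sapiens), read by reporter gene assay (a higher number here means that more compound is needed for the effect, a lower number that less compound is needed), compound 3 gives "not active" (no number reported). It shares this outcome with compound 2, whose structure is `CCOC(=O)CNc1oc2c(C)ncc(CO)c2c1Nc1ccccn1`; in this assay compound 2 gives "not active" (no number reported). For the measured compounds named here, the only compound of the set with a number is compound 1, the structure `CCCCCNc1oc2c(C)ncc(CO)c2c1Nc1ccccn1`, which in this assay gives 5810 nM. Compound 4, the structure `Cc1ncc(CO)c2c(Nc3ccccn3)c(NC(C)C)oc12`, has not yet been measured in this assay. Its change from compound 3 is hydrogen in place of methyl on a saturated chain carbon bound to a nitrogen on an aromatic ring and two saturated chain carbons, the same difference read one bond further out being tert-butyl to isopropyl. Going by the values given here, nothing in the set shows how this assay answers hydrogen in place of methyl on a saturated chain carbon bound to a nitrogen on an aromatic ring and two saturated chain carbons, since no step between measured compounds is known here; compound 3 stands without a number and compound 1 is weak. Compound 4 is therefore expected to be weak as well, most likely closer to the outcome of compound 3 than to a clear number, with a fair chance that this assay again reports no number. Compound 4 is estimated at 15000 nM in this assay, within a range from 4000 nM to 60000 nM.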

Compound 4, half-maximal effective concentration: "not active" (no number reported)
For compound 4 the study gives words and no number, and the estimate cannot be compared.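

In this assay compound 3 gives "not active" (no number reported) and compound 4 gives "not active" (no number reported) so no step can be read between them. No evidence bearing on this result is at hand. The compounds shown leave open how tert-butyl to isopropyl alters agonist activity.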